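Removing the amino group in a series without measurable activity

A few compounds are considered here, and "the series" means these few. Any claim that something is new, unique, unknown or untested is made for them only; others in the source may bear on it.

The measured compounds and their values:
Compound 1, `CCCCC(CCO)n1cnc2c(N)ncnc21`: in a functional assay on SW480 cells (Homo sapiens) for antiproliferative activity, read by MTT assay, with a stated time of 48 h (a lower number here means a stronger inhibitor, a higher number a weaker inhibitor), compound 1 gives > 50000 nM, which is a limit of the assay rather than a number.
Compound 2, `CCCCC(CCO)n1cnc2cncnc21`: in this assay compound 2 gives > 50000 nM, again only a limit.
Compound 3, `CCCCCC(CCO)n1cnc2c(N)ncnc21`: in this assay compound 3 gives > 50000 nM, also a limit.

All three sit at the same place, namely (the limit of > 50000 nM in this assay, at which 3 of the 3 values shown sit). The change from compound 1 to compound 2 is hydrogen in place of amino on an aromatic carbon, and the step it made, a step that the two limits leave unreadable from compound 1 to compound 2, cannot be sized since both ends are limits. The two cores differ by methyl in place of hydrogen on a saturated chain carbon, five bonds along the chain from an aromatic nitrogen, and the corresponding step that the two limits leave unreadable from compound 1 to compound 3 is equally unreadable.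

Compound 4, `CCCCCC(CCO)n1cnc2cncnc21`, has not been measured in this assay. It differs from compound 3 by hydrogen in place of amino on an aromatic carbon, the same change that turns compound 1 into compound 2, since the two descriptions of the place agree word for word. With every measured neighbour at the limit, nothing in the data points toward an onset of activity for compound 4. The step from compound 3 to compound 4 is therefore expected to be a step that the limit leaves unreadable from compound 3 to compound 4, resting on compound 1 and compound 2 both giving only a limit. Compound 4 is expected to give about 100000 nM, within 30000 nM to 400000 nM, most likely reported again as a limit.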

Compound 4, half-maximal inhibitory concentration: > 50000 nM
Compound 4: a limit, no number; the forecaster's own chance of this, stated with the estimate: 85%; the middle value is on the limit's open side.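

In this assay compound 4 gives > 50000 nM, which is a limit and not a number. No new step can be read, neither from compound 3 to compound 4 nor from compound 2 to compound 4, as all four compounds share the same result: the limit of > 50000 nM in this assay, at which 4 of the 4 values shown sit.

The compounds shown leave open whether hydrogen in place of amino, or the added methyl, changes activity in this assay at all.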